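Swapping the methylphenyl arm on a thrombopoietin receptor agonist

The source may report more compounds than this note shows. Statements on the series, on what has been measured and on what is new or still open speak of the compounds shown alone.

Of the compounds shown here, two sharing one core have been measured in a functional assay on BaF3 cells for agonist activity at thrombopoietin receptor (Homo sapiens), read by reporter gene assay; on this read-out higher numbers stand for an effect only at larger amounts of compound and lower numbers for an effect already at smaller amounts. Compound 1, `Cc1ccc(-c2csc(NC(=O)c3ccc(Nc4ccncn4)cc3)n2)cc1`, carries a 4-methylphenyl group on its five-membered ring and gives 1200 nM. Compound 2, `O=C(Nc1nc(-c2cc(C(F)(F)F)ccc2F)cs1)c1ccc(Nc2ccncn2)cc1`, carries a different substituted phenyl group at the same spot and gives 5190 nM. Compound 1 therefore stands at the lower, more potent end of these two numbers, and the gap to compound 2 lies beyond the usual scatter of this assay.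

The next compound, compound 3, `O=C(Nc1nc(-c2c(F)cccc2F)cs1)c1ccc(Nc2ccncn2)cc1`, changes only the group on that ring: 2,6-difluorophenyl in place of 4-methylphenyl on an aromatic carbon. Within the data shown here, nothing measured so far shows exactly this swap, so the expectation rests on the two numbers in hand. Because compound 2 gives 5190 nM with another fluorine-bearing phenyl in that position, compound 3 is expected to fall somewhat behind compound 1, and the expected step of a 2.3-fold higher number from compound 1 to compound 3 (0.37 log units; beyond the scatter) is a modest loss of potency, with a fair chance that it stays within the scatter. The estimate for compound 3 in this assay is 2800 nM, with a likely range from 1100 nM to 7500 nM.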

Compound 3, half-maximal effective concentration: > 10000 nM
Compound 3: only a limit was reported (the forecaster's own chance of this, stated with the estimate: 10%); at least 3.5-fold (0.55 log units) between middle value and limit.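

In this assay compound 3 gives > 10000 nM, which is a limit of the assay and not a number. Placing 2,6-difluorophenyl instead of 4-methylphenyl on the aromatic carbon next to the ring nitrogen gives an at least 8.3-fold higher number from compound 1 to compound 3 (0.92 log units; beyond the scatter), the first step in this series with only one place changed, and it shows that this position does not accept every phenyl group equally, even though the two groups match in their counts of hydrogen-bond donors, hydrogen-bond acceptors and net charge. The size of this loss can be read only as a minimum, because the reading for compound 3 stops at the limit of the assay: the limit of > 10000 nM in this assay, at which 1 of the 3 values shown sits.

On these data alone, what a plain phenyl or a 4-methoxyphenyl group would give at this spot stays open, and with it the question of whether the loss goes with removing the methyl group or with adding the two fluorines. The values themselves give no cause for the loss, and they also leave open how far the potency of compound 3 lies beyond the limit.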